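This account rests on a few compounds, and the source may have more. Where it says the series, first, only, none or still open, it means among the compounds named here.

Going by the values given here, in a functional assay on MIA PaCa-2 cells (Homo sapiens) for cytotoxicity, read by MTT assay, with a stated time of 72 h (a higher number here means a weaker inhibitor, a lower number a stronger inhibitor), compound 1 `O=C1C(Nc2ccc(-c3ccc(Cl)cc3)cc2)=CC(=O)c2ncncc21` gives 9700 nM, the higher of the two numbers measured so far, and compound 2 `O=C1C(Nc2ccc(N3CCCCC3)cc2)=CC(=O)c2ncncc21` gives 2400 nM. The next compound is compound 3 `O=C1C(Nc2ccc(-c3ccccn3)cc2)=CC(=O)c2ncncc21`, with pyridin-2-yl in place of 4-chlorophenyl on an aromatic carbon. Among the compounds with values here, one measured step bears on this change, since it replaces the same 4-chlorophenyl group: a 4.0-fold lower number from compound 1 to compound 2 (0.61 log units; beyond the scatter). That step is modest, and it introduces piperidin-1-yl rather than pyridin-2-yl, so it is only a loose guide. Within the data shown here, no measured compound carries pyridin-2-yl. A smaller move in the same direction is therefore expected, and a result within the scatter of compound 1 would not be surprising. The estimated change is a 1.8-fold lower number from compound 1 to compound 3 (0.25 log units; within the scatter). For compound 3 the expected value is 5500 nM, with an estimated range of 2200 nM to 13000 nM.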

Compound 3, half-maximal inhibitory concentration: 2000 nM
Beside the measured number, compound 3's estimate is 2.8-fold (0.44 log units) above it; the measured number lies below the stated range.
By their numbers in this assay, from the lowest: compounds 3 and 2 (each within the scatter of the next); then compound 1.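

In this assay, pyridin-2-yl in place of 4-chlorophenyl on this aromatic carbon, para to a large group, gives a 4.9-fold lower number from compound 1 to compound 3 (0.69 log units; beyond the scatter) and so shows that a replacement keeping a six-membered aromatic ring can also move the number away from that of compound 1. Going by these compounds alone, the second comparison gives a 1.2-fold lower number from compound 2 to compound 3 (0.08 log units; within the scatter) and so does not separate pyridin-2-yl from piperidin-1-yl at this position, leaving 4-chlorophenyl as the one group of the three with a clearly higher number. No measured evidence on hand accounts for this difference between the groups.

The change from compound 1 to compound 3 removes the chlorine and adds a ring nitrogen in one step, so the contribution of each stays unresolved. Plain phenyl, pyridin-3-yl and morpholin-4-yl at the same position would be the closest open comparisons.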